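Capping the terminal hydroxy of a diyne alcohol

The compounds below may be only part of what the source reports. "The series", "measured", "known", "first", "only" and "open" are said of these compounds alone.

Measured so far:
Compound 1, `C=CCCCCCC#CC#CCO`: 10.8 ug/mL
Compound 2, `C=CCCCCCCCC#CC#CC(O)CC(C)=O`: 4.45 ug/mL
Compound 3, `C=CCCCCCCCC#CC#CCO`: 5.26 ug/mL

All three compounds were tested in a functional assay on XF498 cells (Homo sapiens) for cytotoxicity; a higher number here means that more compound is needed for the effect, a lower number that less compound is needed. Compound 3 sits second highest of the three numbers. Its nearest neighbour is compound 2, and the step of a 1.2-fold higher number from compound 2 to compound 3 (0.07 log units; within the scatter) lies within the scatter, so the two cannot be told apart. Its furthest neighbour is compound 1, and the step of a 2.1-fold lower number from compound 1 to compound 3 (0.31 log units; beyond the scatter) is modest but beyond the scatter.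

Compound 4, `C=CCCCCCCCC#CC#CCOCC(=O)OC`, has not yet been measured in this assay. It differs from compound 3 in one place: (methoxycarbonyl)methyl in place of hydrogen on an oxygen on a saturated carbon. Seen one bond further out, a hydroxy becomes a (methoxycarbonyl)methoxy.

Of the measured steps, only a 1.2-fold higher number from compound 2 to compound 3 (0.07 log units; within the scatter) touches the same end of the molecule, where a carbonyl-bearing group is added or removed at the carbon bearing the oxygen; that step stayed within the scatter. The step of a 2.1-fold lower number from compound 1 to compound 3 (0.31 log units; beyond the scatter) concerns the other end of the chain and says nothing about the oxygen. With one relevant comparison, and that one flat, the expected step of a 1.1-fold lower number from compound 3 to compound 4 (0.02 log units; within the scatter) is none beyond the scatter. Compound 4 is therefore estimated at 5 ug/mL, with a range from 2.2 ug/mL to 11 ug/mL.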

Compound 4, concentration for half-maximal effect: > 30 ug/mL
Compound 4: only a limit was reported (the forecaster's own chance of this, stated with the estimate: 5%); at least 6.0-fold (0.77 log units) between middle value and limit.
By their numbers in this assay, from the lowest: compounds 2 and 3 (each within the scatter of the next); then compound 1. At a limit, above all of these: compound 4.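

Compound 3 carries a free hydroxy, and compound 4 is the only compound shown with a group on that oxygen. In this assay, this single change gives an at least 5.7-fold higher number from compound 3 to compound 4 (0.75 log units; beyond the scatter), so this oxygen is a position where a change can matter. The earlier compounds shown here did not show this: with the hydroxy kept and a 2-oxopropyl on the saturated chain carbon bound to that oxygen, the comparison gives only a 1.2-fold higher number from compound 2 to compound 3 (0.07 log units; within the scatter), which is within the scatter, so a carbonyl-bearing group at that carbon leaves the number flat while the one on the oxygen does not. The value of compound 4 is a limit and not a number: the limit of > 30 ug/mL in this assay, at which 1 of the 4 values shown sits.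

Still open, on these data alone, is whether the step comes from losing the hydrogen of the hydroxy or from what was attached in its place, a question that a simple methyl ether at this oxygen could help to separate. Also open, as far as these compounds go, is how a carboxylic acid in place of the methyl ester would read, and whether the same capping would have a similar effect on the shorter chain of compound 1.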